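Methyl to nitro on a weak adenosine receptor binder

This account rests on a few compounds, and the source may have more. Where it says the series, first, only, none or still open, it means among the compounds named here.

Measured so far:
compound 1: `CCOc1cccc2cc(-c3ccc([N+](=O)[O-])cc3)c(=O)oc12` — > 100000 nM
compound 2: `Cc1ccc(-c2cc3cccc(C)c3oc2=O)cc1` — 16600 nM

Of the compounds shown here, two have been tested in an assay on CHO cells for displacement of a labelled ligand from adenosine receptor A3 (Homo sapiens), read by radioligand binding; a lower number here means a stronger inhibitor, a higher number a weaker inhibitor. Compound 1 `CCOc1cccc2cc(-c3ccc([N+](=O)[O-])cc3)c(=O)oc12` gives only a limit of > 100000 nM, which is not a number. For the measured compounds named here, compound 2 `Cc1ccc(-c2cc3cccc(C)c3oc2=O)cc1` gives 16600 nM in this assay, and this is the only actual number among the two results. Compound 3 `Cc1cccc2cc(-c3ccc([N+](=O)[O-])cc3)c(=O)oc12` has not yet been measured. It differs from compound 2 in one place: nitro in place of methyl on an aromatic carbon. Going by the values given here, no pair of measured compounds shows this change, so the size of the step cannot be read off directly. What is known is that compound 1, which carries the same nitro-bearing ring as compound 3, sits at the limit of > 100000 nM in this assay, at which 1 of the 2 values shown sits. On that basis compound 3 is expected to be the weaker of the pair, with an estimated step of a 3.6-fold higher number from compound 2 to compound 3 (0.56 log units; beyond the scatter), large enough to lie beyond the usual scatter. For compound 3 the expected value in this assay is 60000 nM, with a range from 15000 nM to 300000 nM, and there is a fair chance that only a limit will be reported.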

Compound 3, inhibition constant: > 100000 nM
Compound 3: a limit, no number; the forecaster's own chance of this, stated with the estimate: 50%; middle value at least 1.6-fold (0.22 log units) away from the limit.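

In this assay, for the compounds shown here, nitro in place of methyl on an aromatic carbon, para to a large group, is the first change between two measured compounds whose size can be judged, and it gives an at least 6.0-fold higher number from compound 2 to compound 3 (0.77 log units; beyond the scatter). Compound 3 gives > 100000 nM, which is a limit and not a number. Methyl in place of ethoxy on an aromatic carbon, the change that links the two nitro compounds, cannot be read, and both compounds remain at the same limit, so this second site shows no measurable difference while the nitro group is present: the limit of > 100000 nM in this assay, at which 2 of the 3 values shown sit.

With methyl the only group at this place that yields an actual number, the compounds shown do not tell whether nitro is unusual or whether other replacements, such as an amine, a chlorine atom or a carboxylic acid, would also give a higher number than methyl. Also open, as far as these compounds go, is how ethoxy behaves at the second site when methyl, rather than nitro, sits at the first, since that comparison would not be blocked by a limit on the side of the methyl compound.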